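The source may hold more compounds than are shown below. What is called first, only, known or untested is meant among the compounds shown, and "the series" means these compounds.

In a physicochemical assay for solubility, at pH 7 (on this read-out higher numbers stand for higher solubility and lower numbers for lower solubility), compound 3 `CN1CCN(C(=O)N2Cc3c(NC(=O)c4ccc(F)cc4)n[nH]c3C2(C)C)CC1` gives > 225000 nM, which is a limit and not a number. Compound 1 `CC1(C)c2[nH]nc(NC(=O)c3ccc(F)cc3)c2CN1C(=O)C1CCN(C2CC2)CC1` gives > 225000 nM, also a limit. Every reading so far stands at the same mark, (the limit of > 225000 nM in this assay, at which 3 of the 3 values shown sit), so compound 3 cannot be placed above or below the other compounds.

Compound 4 `CCN1CCC(C(=O)N2Cc3c(NC(=O)c4ccc(F)cc4)n[nH]c3C2(C)C)CC1` differs from compound 3 at a single place: 1-ethylpiperidin-4-yl in place of 4-methylpiperazin-1-yl on a carbonyl carbon. In words, 1-ethylpiperidin-4-yl stands in place of 4-methylpiperazin-1-yl on a carbonyl carbon whose other neighbours are: amide-type nitrogen in a ring.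

For the measured compounds named here, the one measured step at this place is a step that the two limits leave unreadable from compound 1 to compound 3, and it offers no size to carry over. Compound 2 `CCN1CCC(C(=O)N2Cc3c(NC(=O)CC(C)C)n[nH]c3C2(C)C)CC1` already carries 1-ethylpiperidin-4-yl on a carbonyl carbon and shows > 225000 nM, a limit, and the expectation rests on that reading. No step beyond the usual scatter is therefore expected in this assay, and no direction can be assigned.

The expected change is a number no higher from compound 3 to compound 4 (the limit leaves the size open). A report of the limit alone is the most likely outcome for the new compound. As a number, the estimate for compound 4 is 225000 nM, with an expected range from 130000 nM to 400000 nM.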

Compound 4, solubility: > 225000 nM
Compound 4 gave a limit, no number (the forecaster's own chance of this, stated with the estimate: 90%); the middle value sits exactly at the limit.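

In this assay, for the compounds shown here, compound 4 gives > 225000 nM and this is a limit, not a number, so no step to compound 1, compound 2 or compound 3 can be read: the limit of > 225000 nM in this assay, at which 4 of the 4 values shown sit. The compounds shown leave open how far each lies from that limit, and whether swapping any of these groups changes the read-out at all.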